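Amide nitrogen substituent and antiproliferative potency in the series

A few compounds are considered here, and "the series" means these few. Any claim that something is new, unique, unknown or untested is made for them only; others in the source may bear on it.

Three amides of one shared core have been measured in a functional assay on PC-3 cells (Homo sapiens) for antiproliferative activity, read by MTT assay, with a stated time of 48 h; a higher number here means a weaker inhibitor, a lower number a stronger inhibitor. Compound 1 `CCn1c(C(=O)NCCN)ccc1C(CC)(CC)c1ccc(OCCC(O)(CC)CC)c(C)c1` gives 2420 nM. Compound 3 `CCC(C)C(NC(=O)c1ccc(C(CC)(CC)c2ccc(OCCC(O)(CC)CC)c(C)c2)n1CC)C(=O)O` gives 13800 nM. Compound 2 `CCOc1ccc(NC(=O)c2ccc(C(CC)(CC)c3ccc(OCCC(O)(CC)CC)c(C)c3)n2CC)cc1` gives only a limit, > 50000 nM, which is the limit of > 50000 nM in this assay, at which 1 of the 3 values shown sits; compound 2 therefore stands at the weak end of the numbers shown. The measured steps on the amide-type nitrogen run as follows: an at least 20-fold higher number from compound 1 to compound 2 (1.31 log units; beyond the scatter); a 5.7-fold higher number from compound 1 to compound 3 (0.76 log units; beyond the scatter); an at least 3.6-fold lower number from compound 2 to compound 3 (0.55 log units; beyond the scatter).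

Compound 4 `CCn1c(C(=O)N(C)CCO)ccc1C(CC)(CC)c1ccc(OCCC(O)(CC)CC)c(C)c1` is not yet measured. It differs from compound 2 in one place: (2-hydroxyethyl)(methyl)amino in place of (4-ethoxyphenyl)amino on a carbonyl carbon. Of the measured steps, an at least 20-fold higher number from compound 1 to compound 2 (1.31 log units; beyond the scatter) and an at least 3.6-fold lower number from compound 2 to compound 3 (0.55 log units; beyond the scatter) bear on it most, since each moves between the 4-ethoxyphenyl group and a small acyclic group on the same nitrogen, and in each the acyclic group carries the lower number. Compound 4 carries a 2-hydroxyethyl and a methyl rather than the 2-aminoethyl of compound 1, so the full return to the number of compound 1 is not assumed. For compound 4 a step downward beyond the scatter is expected, an at least 6.2-fold lower number from compound 2 to compound 4 (0.79 log units; beyond the scatter). Compound 4 is estimated at 8000 nM, with a range from 2500 nM to 30000 nM.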

Compound 4, half-maximal inhibitory concentration: 3090 nM
Estimate against measurement, compound 4: 2.6-fold (0.41 log units) above, within the range that was stated.
By their numbers in this assay, from the lowest: compounds 1 and 4 (each within the scatter of the next); then compound 3. At a limit, above all of these: compound 2.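

Compound 4 carries no amine and no amide hydrogen on this carbonyl carbon, yet the step from the 2-aminoethyl amide is small: a 1.3-fold higher number from compound 1 to compound 4 (0.11 log units; within the scatter). The 2-aminoethyl group of compound 1 is therefore not needed for a number in this range, and a small acyclic group alone does not fix the number either, as the 1-carboxy-2-methylbutyl group of compound 3 goes against that reading: a 4.5-fold lower number from compound 3 to compound 4 (0.65 log units; beyond the scatter). The large step away from the (4-ethoxyphenyl)amino group, an at least 16-fold lower number from compound 2 to compound 4 (1.20 log units; beyond the scatter), rests on a limit for compound 2: the limit of > 50000 nM in this assay, at which 1 of the 4 values shown sits.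

Open, on these data alone, is which part of the (2-hydroxyethyl)(methyl)amino group matters, since a 2-hydroxyethylamino or a dimethylamino group would separate the hydroxyl from the methyl. Also open, as far as these compounds go, is whether a longer chain, such as 3-hydroxypropyl, or a cyclic amine, such as morpholine, would stay level with compound 1 and compound 4.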